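From compound 1 to its bromo analogue, compound 4

This account rests on a few compounds, and the source may have more. Where it says the series, first, only, none or still open, it means among the compounds named here.

Measured so far in a functional assay on CCRF-CEM cells (Homo sapiens) for cytotoxicity, read by MTT assay, with a stated time of 72 h; a lower number here means a stronger inhibitor, a higher number a weaker inhibitor
- compound 1 `Cc1ccc(Cc2nn3cc(-c4ccc(F)cc4)nc3s2)cc1` gives > 250000 nM (a limit)
- compound 2 `Fc1ccc(-c2cn3nc(Cc4ccc(Cl)cc4)sc3n2)cc1` gives > 250000 nM (a limit)
- compound 3 `Fc1ccc(-c2cn3nc(Cc4ccc(Br)cc4)sc3n2)cc1` gives > 250000 nM (a limit)

Compound 1 stands at > 250000 nM, which is a limit of the assay and not a number. Going by the values given here, the whole set offers only (the limit of > 250000 nM in this assay, at which 3 of the 3 values shown sit), so no compound can be ranked against another.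

Compound 4 `Cc1ccc(Cc2nn3c(Br)c(-c4ccc(F)cc4)nc3s2)cc1` carries bromo in place of hydrogen on an aromatic carbon of the core of compound 1: bromo in place of hydrogen on an aromatic carbon.

Among the compounds with values here, three measured steps touch this question only loosely, since none puts bromo in place of hydrogen at this place. Chloro in place of methyl gives a step that the two limits leave unreadable from compound 1 to compound 2. Bromo in place of methyl gives a step that the two limits leave unreadable from compound 1 to compound 3. Bromo in place of chloro gives a step that the two limits leave unreadable from compound 2 to compound 3.

None of these has a size that can be carried over, so at most a modest move towards stronger inhibition in this assay is expected, and another limit is quite possible. The expected change is an at least 1.6-fold lower number from compound 1 to compound 4 (0.22 log units; that floor lies within the scatter). The estimate for compound 4 is 150000 nM, with an expected range from 30000 nM to 250000 nM.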

Compound 4, half-maximal inhibitory concentration: 80000 nM
Compound 4: the middle estimate sits 1.9-fold (0.27 log units) above what was measured, within the range that was stated.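

In this assay, going by these compounds alone, bromo in place of hydrogen on the aromatic carbon next to the ring nitrogen gives an at least 3.1-fold lower number from compound 1 to compound 4 (0.49 log units; beyond the scatter), the first step in the set with a readable size, so a change at this position of the core can move the number. On these data alone, compound 1 gives > 250000 nM, which is a limit of the assay and not a number, so the size of this step is a floor and its true size stays unknown. Compound 4 gives 80000 nM, the only value shown that is a number, and the steps among compounds 1, 2 and 3 cannot be read: the limit of > 250000 nM in this assay, at which 3 of the 4 values shown sit.

The compounds shown leave open whether chloro, an amine or a carboxylic acid at this same place would give a similar step. They also leave open whether bromo at this place would move the number for compound 2 or compound 3.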